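This account rests on a few compounds, and the source may have more. Where it says the series, first, only, none or still open, it means among the compounds named here.

Measured in an ADME assay on microsomes from liver (Rattus norvegicus) for metabolic stability, using NADPH; on this read-out higher numbers stand for fast clearance and lower numbers for slow clearance:
- compound 1 (`CNC(=O)c1nc(Br)c(C(F)(F)F)cc1N`): 0.1 mL/min/kg
- compound 2 (`Nc1cc(C(F)(F)F)c(Br)nc1C(=O)NC[C@H](O)C(F)(F)F`): 0.023 mL/min/kg

Compound 2, at 0.023 mL/min/kg, holds the lower of the two numbers, and the gap to compound 1 lies beyond the scatter. Compound 3 (`CC(C)(O)CNC(=O)c1nc(Br)c(C(F)(F)F)cc1N`) is still unmeasured. It carries 1-hydroxy-1-methylethyl in place of 2,2,2-trifluoro-1-hydroxyethyl on a saturated chain carbon bound to an amide-type nitrogen. Among the measured compounds shown here, one measured step bears on this, the one that placed the leaving group at that same place (a 4.3-fold lower number from compound 1 to compound 2 (0.64 log units; beyond the scatter)). For the measured compounds named here, no measured compound carries the entering group, so this is only an indirect guide. A partial return towards compound 1 is expected, smaller than that step and close to the edge of the scatter (a 2.2-fold higher number from compound 2 to compound 3 (0.34 log units; beyond the scatter)). In this assay compound 3 is estimated at 0.05 mL/min/kg (expected range 0.015 mL/min/kg to 0.15 mL/min/kg).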

Compound 3, clearance in the Rattus norvegicus assay: < 0.025 mL/min/kg
Compound 3: no number, only a limit; the forecaster's own chance of this, stated with the estimate: 10%; middle value at least 2.0-fold (0.30 log units) from the limit.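

In the Rattus norvegicus assay compound 3 reads < 0.025 mL/min/kg, which is a limit of the assay and not a number, so the step from compound 2 cannot be read. In the Rattus norvegicus assay 1-hydroxy-1-methylethyl also gives an at least 4.0-fold lower number from compound 1 to compound 3 (0.60 log units; beyond the scatter), so a lower number at this place is not confined to 2,2,2-trifluoro-1-hydroxyethyl. In a physicochemical assay for solubility, at pH 6.8 (a higher number here means a more soluble compound, a lower number a less soluble compound), compound 2 gives 290 ug/mL and compound 3 gives 28 ug/mL. In the physicochemical assay the same exchange of groups does separate the two compounds: the measured solubility of compound 2, 290 ug/mL, and of compound 3, 28 ug/mL, a 10-fold lower number (1.02 log units; beyond the scatter)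

Going by these compounds, the true position of compound 3 in the Rattus norvegicus assay, and with it any order of compound 2 and compound 3, stays open: the limit of < 0.025 mL/min/kg in the Rattus norvegicus assay, at which 1 of the 3 values shown sits. Also open is whether an amine, a carboxylic acid or a longer chain on a saturated chain carbon bound to an amide-type nitrogen would combine a clearance number this low with the solubility of compound 2.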